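A few compounds are considered here, and "the series" means these few. Any claim that something is new, unique, unknown or untested is made for them only; others in the source may bear on it.

In a functional assay on the whole organism for antagonist activity, with Mus musculus as the target, in the maximal electroshock model (a higher number here means that more compound is needed for the effect, a lower number that less compound is needed), compound 3 `Cn1c(-c2cccs2)nnc1[S+](C)[O-]` gives > 200 mg/kg, which is a limit and not a number. Compound 2 `CSc1n[nH]c(-c2ccc(F)cc2)n1` gives > 200 mg/kg, again a limit. Compound 1 `Cn1c(-c2cccc(F)c2)nnc1S(C)(=O)=O`, which bears a methylsulfonyl group, gives > 200 mg/kg, also a limit. The measurements therefore show only (the limit of > 200 mg/kg in this assay, at which 3 of the 3 values shown sit), and compound 3 cannot be ranked against the other two.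

Compound 4 `Cn1c(-c2cccs2)nnc1S(C)(=O)=O` differs from compound 3 in one place, on an aromatic carbon between two ring nitrogen atoms, where methylsulfonyl enters: a group of 4 heavy atoms (1 carbon, 2 oxygen, 1 sulfur; no ring) in place of a group of 3 heavy atoms (1 carbon, 1 oxygen, 1 sulfur; no ring), on an aromatic carbon. Among the measured compounds shown here, no measured pair of compounds shows what this kind of change does. The closest guide is compound 1, whose methylsulfonyl group comes with > 200 mg/kg, so no step beyond the usual scatter is expected in this assay. The estimated step is a number no higher from compound 3 to compound 4 (the limit leaves the size open), and it is uncertain because it starts from a limit rather than a number. Compound 4 is expected at 200 mg/kg, within an estimated range from 80 mg/kg to 400 mg/kg, and it may well be reported only as a limit.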

Compound 4, dose for half-maximal effect: > 200 mg/kg
Compound 4 was reported as a limit (the forecaster's own chance of this, stated with the estimate: 65%); the middle value sits exactly at the limit.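

No step can be read from compound 3 to compound 4, since both results in this assay are limits and not numbers: the limit of > 200 mg/kg in this assay, at which 4 of the 4 values shown sit. The compounds shown leave open whether methylsulfonyl changes the dose needed at all, and how the four compounds rank against one another.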